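The source may hold more compounds than are shown below. What is called first, only, known or untested is meant among the compounds shown, and "the series" means these compounds.

Measured compounds:
- compound 1, `CCN(CC)S(=O)(=O)c1ccc(S(=O)(=O)N2CCC[C@@H](C(=O)N3CCC(COC)CC3)C2)cc1`, 250 nM
- compound 2, `CCN(CC)S(=O)(=O)c1ccc(S(=O)(=O)N2CCC[C@@H](C(=O)N3CC[C@@H](OC)C3)C2)cc1`, 3910 nM

Going by the values given here, compound 2 gives the highest number of the two in a functional assay on MIA PaCa-2 cells (Homo sapiens) for inhibition, read by MTT assay, with a stated time of 7 days; a higher number here means a weaker inhibitor, a lower number a stronger inhibitor; its nearest neighbour is compound 1, and the only step in the set, a 16-fold higher number from compound 1 to compound 2 (1.19 log units; beyond the scatter), separates them.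

The unmeasured compound 3, `CCN(CC)S(=O)(=O)c1ccc(S(=O)(=O)N2CCC[C@@H](C(=O)N3CCC(C(F)F)CC3)C2)cc1`, differs from compound 2 by 4-(difluoromethyl)piperidin-1-yl in place of 3-methoxypyrrolidin-1-yl on a carbonyl carbon. This change reverses the ring part of the measured step: the six-membered ring with a substituent at the 4-position, as in compound 1, returns, while the substituent itself is now difluoromethyl rather than methoxymethyl and carries no hydrogen-bond acceptor. The step of a 16-fold higher number from compound 1 to compound 2 (1.19 log units; beyond the scatter) is the one that bears on this, and it was large. Among the compounds with values here, for compound 3 a step down in this assay that recovers much, though not necessarily all, of that ground is therefore expected, since the substituent on the six-membered ring is not the one of compound 1.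

Compound 3 is estimated at 500 nM, within 150 nM to 2000 nM, an expected step of a 7.8-fold lower number from compound 2 to compound 3 (0.89 log units; beyond the scatter).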

Compound 3, half-maximal inhibitory concentration: 420 nM
The estimate for compound 3 lay 1.2-fold (0.08 log units) above the measured number, within the range that was stated.
By their numbers in this assay, from the lowest: compounds 1 and 3 (each within the scatter of the next); then compound 2.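

In this assay, the 4-(difluoromethyl)piperidin-1-yl amide restores most of what the 3-methoxypyrrolidin-1-yl amide lacks (a 9.3-fold lower number from compound 2 to compound 3 (0.97 log units; beyond the scatter)), so the large gap first seen between compound 1 and compound 2 is not tied to the methoxymethyl group alone. Difluoromethyl in place of methoxymethyl on a saturated ring carbon gives a 1.7-fold higher number from compound 1 to compound 3 (0.23 log units; within the scatter), and compound 1 and compound 3 therefore cannot be told apart in this read-out, even though the substituent in compound 3 carries no hydrogen-bond acceptor by the count for this group. Among these three compounds, the two 4-substituted piperidin-1-yl amides stand together and the 3-methoxypyrrolidin-1-yl amide stands apart, with no compound against that grouping, but the ring and its substituent change together in both steps that involve compound 2.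

Ring size therefore remains unseparated from substituent identity and position, and the unsubstituted piperidin-1-yl, 4-methoxypiperidin-1-yl and 3-(difluoromethyl)pyrrolidin-1-yl amides would be the groups that could pull these apart. No measurement offered here explains why the numbers fall as they do.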